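The compounds below may be only part of what the source reports. "The series", "measured", "known", "first", "only" and "open" are said of these compounds alone.

Measured so far:
compound 1 `Cn1c(-c2ccc(F)cc2)nc2c(NC3CCCC3)ncnc21` — > 30000 nM
compound 2 `Cn1c(-c2ccccc2)nc2c(NC3CCOC3)ncnc21` — 13300 nM

All readings come from a functional assay on CHO cells for antagonist activity at adenosine receptor A2b (Homo sapiens), read by 33P incorporation, with a stated time of 20 min; a higher number here means a weaker inhibitor, a lower number a stronger inhibitor. The value for compound 1 is a limit of the assay, not a number. Among the measured compounds shown here, compound 2 is therefore the only compound of the pair with a measured number in this assay, at 13300 nM. Compound 3 `Cn1c(-c2ccccc2)nc2c(NC3CCCC3)ncnc21` differs from compound 2 in one place: cyclopentyl in place of oxolan-3-yl on a nitrogen on an aromatic ring. For the measured compounds named here, no pair differing in one place has been measured on both sides, so the size of this step has not been observed directly. Compound 1 also carries the cyclopentyl group and sits at the limit of > 30000 nM in this assay, at which 1 of the 2 values shown sits. On that basis compound 3 is expected to inhibit more weakly than compound 2 does. The step estimated here is a 1.9-fold higher number from compound 2 to compound 3 (0.27 log units; within the scatter), in the direction of weaker inhibition. The estimate for compound 3 is 25000 nM, within 8000 nM to 60000 nM, and a limit rather than a number is a real possibility.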

Compound 3, inhibition constant: 8510 nM
Compound 3: middle estimate off by 2.9-fold (0.47 log units), on the high side; low and high end bracket the measured number.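

In this assay, cyclopentyl in place of oxolan-3-yl on a nitrogen on an aromatic ring gives a 1.6-fold lower number from compound 2 to compound 3 (0.19 log units; within the scatter), so the two rings cannot be told apart at this position. Hydrogen in place of fluoro on an aromatic carbon, with cyclopentyl kept, gives an at least 3.5-fold lower number from compound 1 to compound 3 (0.54 log units; beyond the scatter), the first step in the series beyond the scatter, and it lies away from the amino substituent. The true size of that step stays open, as compound 1 rests on a limit and not a number: the limit of > 30000 nM in this assay, at which 1 of the 3 values shown sits.

As far as these compounds go, whether an open-chain group such as a longer alkyl chain, or a ring carrying a primary amine or a carboxylic acid, would shift the number beyond the scatter at the amino nitrogen remains open. Also open, from the compounds shown here alone, is whether the fluoro step recurs with oxolan-3-yl in place of cyclopentyl, and how chloro or methoxy would read on that aromatic carbon.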